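A few compounds are considered here, and "the series" means these few. Any claim that something is new, unique, unknown or untested is made for them only; others in the source may bear on it.

Measured so far in a toxicity assay on CCRF-CEM cells (Homo sapiens) for cytotoxicity; on this read-out lower numbers stand for higher toxicity in this test and higher numbers for lower toxicity in this test:
compound 1, `COc1cccc2c1nc(-c1c(F)cccc1F)n2Cc1c(F)cccc1F`, gives 44.3 uM;
compound 2, `COC(=O)c1cccc2c1nc(-c1c(F)cccc1F)n2Cc1c(F)cccc1F`, gives 57.7 uM;
compound 3, `Oc1cccc2c1nc(-c1c(F)cccc1F)n2Cc1c(F)cccc1F`, gives > 100 uM.

The value for compound 3 is a limit of the assay, not a number: compound 3 sits at the limit of > 100 uM in this assay, at which 1 of the 3 values shown sits, so only a limit is known for compound 3. Compound 4, `CC(C)c1cccc2c1nc(-c1c(F)cccc1F)n2Cc1c(F)cccc1F`, differs from compound 3 in one place: isopropyl in place of hydroxy on an aromatic carbon. Two measured steps end at compound 3 and so bear on this change. an at least 2.2-fold higher number from compound 1 to compound 3 (0.35 log units; beyond the scatter). an at least 1.7-fold higher number from compound 2 to compound 3 (0.23 log units; that floor lies within the scatter). Among the compounds with values here, only the step from compound 1 counts as real on the scatter, and the change to compound 4 removes the hydroxy that this step introduced, putting isopropyl in its place. The change to compound 4 is therefore expected to bring the number back toward those of compound 1 and compound 2, as an at least 2.8-fold lower number from compound 3 to compound 4 (0.45 log units; beyond the scatter). In this assay compound 4 is expected to give about 35 uM, somewhere between 12 uM and 100 uM.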

Compound 4, half-maximal toxic concentration: 27 uM
The estimate for compound 4 lay 1.3-fold (0.11 log units) above the measured number, within the range that was stated.
By their numbers in this assay, from the lowest: compounds 4, 1 and 2 (each within the scatter of the next, the first and the last beyond it). At a limit, above all of these: compound 3.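

In this assay, putting isopropyl in place of the hydroxy gives a clear drop (an at least 3.7-fold lower number from compound 3 to compound 4 (0.56 log units; beyond the scatter)), so compound 3 stands apart from the other three compounds, and the shared core alone does not set its high reading. The reading for compound 3 is a limit of the assay, not a number: the limit of > 100 uM in this assay, at which 1 of the 4 values shown sits. Among the compounds without hydroxy, this position now shows its first gap beyond the scatter (a 2.1-fold lower number from compound 2 to compound 4 (0.33 log units; beyond the scatter)), while isopropyl and methoxy remain within the scatter of each other (a 1.6-fold lower number from compound 1 to compound 4 (0.22 log units; within the scatter)).

The compounds shown leave open whether an amine or a carboxylic acid at this position would also give a high number, as the hydroxy does. They also leave open whether a longer carbon chain would lower the number further than isopropyl.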